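Reversing the purine-for-uracil swap on a nitrophenyl sulfonamide

The compounds below may be only part of what the source reports. "The series", "measured", "known", "first", "only" and "open" are said of these compounds alone.

In a functional assay on MCF7 cells (Homo sapiens) for antiproliferative activity (on this read-out lower numbers stand for stronger inhibition and higher numbers for weaker inhibition), compound 3 `O=[N+]([O-])c1ccc(S(=O)(=O)N2CC(n3cnc4c(Cl)ncnc43)OCc3ccccc32)cc1` gives 2730 nM, the second highest of the three numbers recorded; its nearest neighbour is compound 2 `O=[N+]([O-])c1ccccc1S(=O)(=O)N1CC(n2cnc3c(Cl)ncnc32)OCc2ccccc21`, which gives 2100 nM, and the step of a 1.3-fold higher number from compound 2 to compound 3 (0.11 log units; within the scatter) lies within the scatter. The furthest is compound 1 `O=c1ccn(C2CN(S(=O)(=O)c3ccccc3[N+](=O)[O-])c3ccccc3CO2)c(=O)[nH]1`, which gives 45200 nM. Compound 4 `O=c1ccn(C2CN(S(=O)(=O)c3ccc([N+](=O)[O-])cc3)c3ccccc3CO2)c(=O)[nH]1` differs from compound 3 by a group of 8 heavy atoms (4 carbon, 2 nitrogen, 2 oxygen; one six-membered aromatic ring with 2 hetero atoms) in place of a group of 10 heavy atoms (5 carbon, 4 nitrogen, 1 chlorine; one five-membered aromatic ring with 2 hetero atoms, one six-membered aromatic ring with 2 hetero atoms), on a saturated ring carbon. The measured step that bears directly on this change is the reverse one, a 22-fold lower number from compound 1 to compound 2 (1.33 log units; beyond the scatter), a large drop when the chloropurine replaced the uracil on the shared core. The step of a 1.3-fold higher number from compound 2 to compound 3 (0.11 log units; within the scatter) shows that moving the nitro group on the sulfonyl phenyl hardly matters, so compound 4 is expected to sit close to compound 1. The author therefore expects a large upward step a 16-fold higher number from compound 3 to compound 4 (1.22 log units; beyond the scatter) in this assay. The estimate for compound 4 is 45000 nM, with a range from 15000 nM to 130000 nM.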

Compound 4, half-maximal inhibitory concentration: 39800 nM
Beside the measured number, compound 4's estimate is 1.1-fold (0.05 log units) above it; low and high end bracket the measured number.
By their numbers in this assay, from the lowest: compounds 2 and 3 (each within the scatter of the next); then compounds 4 and 1 (each within the scatter of the next).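

In this assay, returning to the group with a single six-membered aromatic ring on the saturated ring carbon next to the ring oxygen brings a 15-fold higher number from compound 3 to compound 4 (1.16 log units; beyond the scatter). The large gap between the two groups at this position therefore appears with the 4-nitrophenyl as well as the 2-nitrophenyl on the sulfonyl sulfur: the same change on two cores in this assay, a 22-fold lower number (1.33 log units; beyond the scatter) from compound 1 to compound 2 and a 15-fold lower number (1.16 log units; beyond the scatter) from compound 4 to compound 3, 1.5-fold (0.17 log units) apart, within the scatter of two such steps Moving the nitro group also remains without a readable effect when the single-ring group is present, with a 1.1-fold lower number from compound 1 to compound 4 (0.06 log units; within the scatter), so the two changes show no sign of depending on each other here: the same change on two cores in this assay, a 1.3-fold higher number (0.11 log units; within the scatter) from compound 2 to compound 3 and a 1.1-fold lower number (0.06 log units; within the scatter) from compound 1 to compound 4, 1.5-fold (0.17 log units) apart, within the scatter of two such steps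

The compounds shown do not separate the contribution of the chlorine from that of the second ring in the larger group. As far as these compounds go, whether an amine in place of that chlorine would keep the lower numbers remains open, as does the effect of a carboxylic acid in place of the nitro group.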